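The source may hold more compounds than are shown below. What is called first, only, known or untested is meant among the compounds shown, and "the series" means these compounds.

Measured:
compound 1, `CC(C(=O)NCc1ccc(C(F)(F)F)nc1SCCOc1ccccc1)c1ccc(NS(C)(=O)=O)c(F)c1`: 2.3 nM
compound 2, `CC(C(=O)NCc1ccc(C(F)(F)F)nc1SCCCO)c1ccc(NS(C)(=O)=O)c(F)c1`: "not active" (no number reported)

Among the measured compounds shown here, compound 1 holds the only number in an assay on CHO-K1 cells for antagonist activity at transient receptor potential cation channel subfamily V member 1 (Homo sapiens), read by FLIPR; on this read-out higher numbers stand for weaker inhibition and lower numbers for stronger inhibition; compound 2 gives "not active" (no number reported) in this assay, with no number behind it, so no step between them can be sized. Compound 3, `CC(C(=O)NCc1ccc(C(F)(F)F)nc1SCc1ccc(Cl)cc1)c1ccc(NS(C)(=O)=O)c(F)c1`, differs from compound 1 by 4-chlorophenyl in place of phenoxymethyl on a saturated chain carbon bound to a sulfur. Compound 2 lacks any six-membered aromatic ring of carbon only on that chain, while compound 3 keeps one, so the step expected is modest and, if anything, toward weaker inhibition: a 2.6-fold higher number from compound 1 to compound 3 (0.42 log units; beyond the scatter). Compound 3 is estimated at 6 nM, between 1.5 nM and 30 nM.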

Compound 3, inhibition constant: 8.7 nM
Estimate against measurement, compound 3: 1.5-fold (0.16 log units) below; measured number inside the range.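

In this assay, the change from (2-phenoxyethyl)sulfanyl to (4-chlorobenzyl)sulfanyl gives a 3.8-fold higher number from compound 1 to compound 3 (0.58 log units; beyond the scatter), so this position accepts 4-chlorophenyl in place of phenoxymethyl at a modest cost. Compound 3 retains a measured number without the oxygen of phenoxymethyl, while the step to compound 2 cannot be read. Nothing available explains the size of this step.

The compounds shown leave open whether the step follows the chlorine or the shorter chain, which change together here. From the compounds shown here alone, how a plain benzyl or a chain-bound amine would read also remains open.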